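A few compounds are considered here, and "the series" means these few. Any claim that something is new, unique, unknown or untested is made for them only; others in the source may bear on it.

Compound 1 `CC(C)N(Cc1cccc(OCCCCCC(=O)O)c1)C(=O)c1ccc(-c2cccc(-c3ccccc3)c2)cc1` carries a free carboxylic acid at the end of its side chain. In an ADME assay on HEK293 cells (Homo sapiens) for cytotoxicity, read by CellTiter-Glo and resazurin assay, with a stated time of 72 h (on this read-out lower numbers stand for an effect already at smaller amounts and higher numbers for an effect only at larger amounts of compound), compound 1 gives > 26000 nM, which is a limit of the assay rather than a number. Compound 2 `CC(C)N(Cc1cccc(OCCCCCC(=O)O)c1)C(=O)c1ccc(-c2ccco2)cc1` differs from compound 1 only in the aromatic group at the far end. In this assay compound 2 also gives > 26000 nM, again a limit and not a number. The step that the two limits leave unreadable from compound 1 to compound 2 therefore cannot be sized, because the limit of > 26000 nM in this assay, at which 2 of the 2 values shown sit, and so both values sit at the same boundary.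

Compound 3 `CCOC(=O)CCCCCOc1cccc(CN(C(=O)c2ccc(-c3cccc(-c4ccccc4)c3)cc2)C(C)C)c1` is the next case: the change is ethyl in place of hydrogen on an oxygen next to a carbonyl group, so the acid of compound 1 becomes its ethyl ester. For the measured compounds named here, no measured step tells how such a change plays out here, since the only step that exists stays hidden behind the limit. With compound 1 standing at a limit, the expected step that the limit leaves unreadable from compound 1 to compound 3 is no more than a guess with no readable precedent. For compound 3 the estimated value in this assay is 30000 nM, in an expected range from 8000 nM to 120000 nM, and a further limit rather than a number is the more likely outcome.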

Compound 3, half-maximal effective concentration: > 26000 nM
Compound 3: a limit, no number (the forecaster's own chance of this, stated with the estimate: 70%); the middle value is on the limit's open side.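

In this assay compound 3 gives > 26000 nM, which is a limit of the assay and not a number. Compound 1 also stands at a limit, so no step from compound 1 to compound 3 can be read, because both sit at one boundary: the limit of > 26000 nM in this assay, at which 3 of the 3 values shown sit.

The compounds shown leave open at what concentration, if any, compound 1, compound 2 or compound 3 would affect these cells.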